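A few compounds are considered here, and "the series" means these few. Any claim that something is new, unique, unknown or untested is made for them only; others in the source may bear on it.

Within the data shown here, compound 2 `CCOc1ccc(-c2cccc(C(=O)OCCOC)c2)cc1` gives 70000 nM in an assay on COS-7 cells for inhibition of patatin-like phospholipase domain-containing protein 2 (Mus musculus) (on this read-out lower numbers stand for stronger inhibition and higher numbers for weaker inhibition), and it is the only compound with an actual number there. Compound 1 `CCOc1ccc(-c2cccc(C(=O)O)c2)cc1` reaches only a limit of the assay, > 200000 nM. Among the measured compounds shown here, the single measured step, an at least 2.8-fold lower number from compound 1 to compound 2 (0.45 log units; beyond the scatter), is therefore the only guide, and it is itself a lower bound on the gain because one end sits at the limit of > 200000 nM in this assay, at which 1 of the 2 values shown sits. Compound 3 `CCOc1ccc(-c2cccc(C(=O)NC)c2)cc1` differs from compound 2 in that (methylamino in place of 2-methoxyethoxy on a carbonyl carbon). For the measured compounds named here, the measured step bears only loosely on this change: there hydrogen was replaced by 2-methoxyethyl, whereas here the whole 2-methoxyethoxy group leaves and methylamino enters, so no measured compound carries an amide. With this thin footing, the expectation is for a step of no change at the digits printed from compound 2 to compound 3 (within the scatter), close to no change beyond the scatter. Compound 3 is estimated at 70000 nM, within a range from 20000 nM to 250000 nM, in this assay.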

Compound 3, half-maximal inhibitory concentration: > 200000 nM
Compound 3: a limit, no number; the forecaster's own chance of this, stated with the estimate: 30%; at least 2.8-fold (0.45 log units) between middle value and limit.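

In this assay, methylamino in place of 2-methoxyethoxy on this carbonyl carbon gives an at least 2.8-fold higher number from compound 2 to compound 3 (0.45 log units; beyond the scatter), so the gain seen with the 2-methoxyethyl group on oxygen does not carry over to this small amide. Among hydroxy, 2-methoxyethoxy and methylamino on this carbon, only 2-methoxyethoxy gives an actual number. The step between compound 1 and compound 3 cannot be read because both sit at the same limit: the limit of > 200000 nM in this assay, at which 2 of the 3 values shown sit.

On these data alone, compound 3 gives > 200000 nM, which is a limit of the assay, so the true size of its loss stays open. Also open, as far as these compounds go, is whether a plain methoxy group on the same carbonyl carbon, or a 2-methoxyethylamino group carrying the same chain on nitrogen, would keep the activity of compound 2.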